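Lengthening the chain on a well-tolerated compound

This account rests on a few compounds, and the source may have more. Where it says the series, first, only, none or still open, it means among the compounds named here.

Measured in an ADME assay on HEL cells (Homo sapiens) for cytotoxicity, with a stated time of 3 days; a lower number here means that less compound is tolerated, a higher number that more compound is tolerated:
- Compound 1 `CCCCCc1ccc(-c2cc3cn([C@H]4C[C@H](O)[C@@H](CO)O4)c(=O)nc3o2)cn1`: > 50000 nM (a limit)
- Compound 2 `CCCc1ccc(C#Cc2cc3cn([C@H]4C[C@H](O)[C@@H](CO)O4)c(=O)nc3o2)cc1`: > 120000 nM (a limit)

Compound 2 has no exact number, and its result is a limit of > 120000 nM. Compound 1 is also known only as a limit, > 50000 nM.

Compound 3 `CCCCCc1ccc(C#Cc2cc3cn([C@H]4C[C@H](O)[C@@H](CO)O4)c(=O)nc3o2)cc1` differs from compound 2 by one change: ethyl in place of hydrogen on a saturated chain carbon, three bonds along the chain from an aromatic carbon. This has ethyl in place of hydrogen on a saturated chain carbon, turning propyl into pentyl. Within the data shown here, no measured pair shows this change, so in this assay no step beyond the usual scatter is expected. The estimated step is an at least 1.2-fold lower number from compound 2 to compound 3 (0.07 log units; that floor lies within the scatter). The expected value for compound 3 is 100000 nM, within an estimated range of 40000 nM to 250000 nM.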

Compound 3, half-maximal cytotoxic concentration: 110000 nM
Compound 3: middle estimate off by 1.1-fold (0.04 log units), on the low side, and the stated range covers the measured number.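

Among these compounds, compound 3 gives the first exact number in this assay, 110000 nM, so the tolerated concentration can now be read directly on this chain. Turning propyl into pentyl gives an at least 1.0-fold lower number from compound 2 to compound 3 (0.03 log units; that floor lies within the scatter), so the longer chain shows no step beyond the usual scatter. The true size of the step stays unknown because compound 2 is known only as a limit: the limit of > 120000 nM in this assay, at which 1 of the 3 values shown sits.

Going by these compounds, whether a chain longer than pentyl, or an amine at the end of the chain, would lower the number remains open.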